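This account rests on a few compounds, and the source may have more. Where it says the series, first, only, none or still open, it means among the compounds named here.

Compound 1 `CC(C)C1C(=O)N(C)c2cnc(Nc3ccc(S(N)(=O)=O)cc3)nc2N1C` is the starting point. In an assay on Sf9 cells for inhibition of serine/threonine-protein kinase 4 (Homo sapiens), read by luminescence and ADP-Glo, with a stated time of 1 h, in the presence of a further agent that is not named here (on this read-out higher numbers stand for weaker inhibition and lower numbers for stronger inhibition), compound 1 gives 254 nM, the highest of the three numbers shown, though both of its neighbours lie within the scatter of it. Compound 2 `CN1C(=O)C(c2cccc(F)c2)N(C)c2nc(Nc3ccc(S(N)(=O)=O)cc3)ncc21` gives 134 nM in this assay, and compound 3 `COc1ccccc1C1C(=O)N(C)c2cnc(Nc3ccc(S(N)(=O)=O)cc3)nc2N1C` gives 251 nM. The two steps that bear on the new compound are a 1.9-fold lower number from compound 1 to compound 2 (0.28 log units; within the scatter) and a 1.0-fold lower number from compound 1 to compound 3 (0.01 log units; within the scatter); neither moved the number beyond the scatter. Compound 4 `CN1C(=O)C(c2c(F)cccc2F)N(C)c2nc(Nc3ccc(S(N)(=O)=O)cc3)ncc21` differs from compound 1 by 2,6-difluorophenyl in place of isopropyl on a saturated ring carbon. Since aryl groups on that carbon have so far changed little, compound 4 is expected to show a 1.4-fold lower number from compound 1 to compound 4 (0.15 log units; within the scatter), with an estimated value of 180 nM and a range from 70 nM to 450 nM.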

Compound 4, half-maximal inhibitory concentration: 42 nM
The estimate for compound 4 lay 4.3-fold (0.63 log units) above the measured number; the measured number lies below the stated range.
By their numbers in this assay, from the lowest: compound 4; then compounds 2, 3 and 1 (each within the scatter of the next).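

Among the compounds shown here, the 2,6-difluorophenyl group is the first on this saturated ring carbon to move the number beyond the scatter in this assay: the compounds show a 6.0-fold lower number from compound 1 to compound 4 (0.78 log units; beyond the scatter) and a 6.0-fold lower number from compound 3 to compound 4 (0.78 log units; beyond the scatter) and also a 3.2-fold lower number from compound 2 to compound 4 (0.50 log units; beyond the scatter). The position therefore responds to which aryl group it carries, which the 3-fluorophenyl and 2-methoxyphenyl groups, both within the scatter of isopropyl, did not show. No measurement at hand accounts for this difference. The compounds leave open whether a 2,6-dichlorophenyl or 2-fluorophenyl group would give a similar number, and how an aminomethyl or carboxylic acid group on the phenyl ring would read.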